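The source may hold more compounds than are shown below. What is called first, only, known or untested is meant among the compounds shown, and "the series" means these compounds.

Working notes on the series. In a physicochemical assay for lipophilicity (on this read-out higher numbers stand for higher lipophilicity and lower numbers for lower lipophilicity), compound 1 `COc1c(OC)c(OC(C)=O)c2c(Cl)cccc2c1OC(C)=O` gives 3.16, compound 2 `COc1c(OC)c(OC(=O)C(C)(C)C)c2c(Cl)cccc2c1OC(=O)C(C)(C)C` gives 6.1 and compound 3 `COc1c(OC)c(OC(C)=O)c2c(OC)cccc2c1OC(C)=O` gives 2.43, the lowest of the three numbers. The next change leads to compound 4 `COc1c(OC)c(OC(C)=O)c2c(C)cccc2c1OC(C)=O`, with methyl in place of methoxy on an aromatic carbon. Among the compounds with values here, the one measured step that bears on it is a number 0.73 log units lower from compound 1 to compound 3 (beyond the scatter), with methoxy in place of chloro on an aromatic carbon. Compound 2 is linked to neither by a single change. Within the data shown here, no measured compound yet carries methyl, so the size remains uncertain. A modest upward step in this assay is expected, a little smaller than that earlier one: a number 0.52 log units higher from compound 3 to compound 4 (beyond the scatter). For compound 4 the estimated value is 2.95, with an expected range of 2.6 to 3.3.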

Compound 4, partition coefficient: 2.8
The estimate for compound 4 lay 0.15 log units above the measured number; the measured number falls inside the stated range.
By their numbers in this assay, from the lowest: compound 3; then compound 4; then compound 1; then compound 2.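

The steps of a number 0.37 log units higher from compound 3 to compound 4 (beyond the scatter) and a number 0.36 log units lower from compound 1 to compound 4 (beyond the scatter) place methyl roughly midway in the order methoxy, methyl, chloro at this aromatic carbon, and both steps lie beyond the usual scatter. Within the data shown here, this gives the position three points on the shared core where the earlier compounds gave only two. Nothing available accounts for this order.

On these data alone, whether an amine or a carboxylic acid at this carbon would fall inside or outside this span remains open. Also open, as far as these compounds go, is whether the same order holds on the core of compound 2.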